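A stereocentre left undrawn in the series

A few compounds are considered here, and "the series" means these few. Any claim that something is new, unique, unknown or untested is made for them only; others in the source may bear on it.

In a functional assay on DU-145 cells (Homo sapiens) for cytotoxicity, read by MTT assay (on this read-out higher numbers stand for weaker inhibition and lower numbers for stronger inhibition), compound 1 `CCC(O)CO[C@H](CC=C(C)C)C1=CC(=O)c2c(O)ccc(O)c2C1=O` gives 16400 nM and compound 2 `CC[C@@](C)(O)CC(=O)O[C@H](CC=C(C)C)C1=CC(=O)c2c(O)ccc(O)c2C1=O` gives 12700 nM so compound 2 stands level with compound 1 on the two numbers available. For the measured compounds named here, the one measured step is a 1.3-fold lower number from compound 1 to compound 2 (0.11 log units; within the scatter) and it puts (2-hydroxy-2-methylbutyl)carbonyl in place of 2-hydroxybutyl on an oxygen on a saturated carbon. Against compound 2, compound 3 `CCC(C)(O)CC(=O)O[C@H](CC=C(C)C)C1=CC(=O)c2c(O)ccc(O)c2C1=O` shows the two compounds have the same atoms and bonds; at least one stereo element is drawn with a configuration in one of them and without one in the other: 1 of 2 stereo elements differ; a stereocentre at a saturated chain carbon is drawn R in compound 2 and without a configuration in compound 3 and the stereocentre at a saturated chain carbon, drawn R in compound 2, has no configuration drawn in compound 3. Going by the values given here, no measured pair isolates a stereocentre, so that step bears on this one only indirectly, as a larger structural change that stayed within the scatter. For compound 3 the expected step is a 1.0-fold higher number from compound 2 to compound 3 (0.01 log units; within the scatter) and so none beyond the scatter. Compound 3 is estimated at 13000 nM (range 7500 nM to 22000 nM).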

Compound 3, half-maximal inhibitory concentration: 16000 nM
For compound 3 the middle estimate is 1.2-fold (0.09 log units) below the measured one, within the range that was stated.
By their numbers in this assay, from the lowest: compounds 2, 3 and 1 (each within the scatter of the next).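

Working notes: in this assay, removing the drawn R configuration at the saturated chain carbon gives a 1.3-fold higher number from compound 2 to compound 3 (0.10 log units; within the scatter), so this stereocentre, as drawn, makes no difference that can be read. The side-chain exchange also stays small when that centre is undrawn, at a 1.0-fold lower number from compound 1 to compound 3 (0.01 log units; within the scatter), so it now reads the same way with the configuration drawn and undrawn. The stereo comparison itself rests on a difference of drawing only: the fact that one of compounds 2 and 3 is drawn with a defined configuration and the other without, at the place where they differ.

Going by these compounds, whether compound 3 is a single form or a mixture stays open, as does how the S form would read, so a real effect of configuration is not excluded. Also open, on these data alone, is whether an amine, a carboxylic acid or a longer chain on that oxygen would move the number beyond the scatter.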